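A ring swap on the sulfur-linked chain carbon

The source may hold more compounds than are shown below. What is called first, only, known or untested is meant among the compounds shown, and "the series" means these compounds.

Two measured compounds share one core and differ only in the group sitting on a saturated chain carbon bound to a sulfur. Compound 1 `N#Cc1c(N)nc(SCC(=O)NCO)c(C#N)c1-c1ccc(OCC2CC2)cc1` carries a (hydroxymethyl)carbamoyl group there, and in an assay on CHO cells for displacement of a labelled ligand from adenosine receptor A3 (Homo sapiens), read by scintillation counting, with a stated time of 120 min, tested at 1 uM (a lower number here means less inhibition, a higher number more inhibition at the concentration tested (going by the name of the read-out)), compound 1 gives 8%. Compound 2 `N#Cc1c(N)nc(SCc2ccn[nH]2)c(C#N)c1-c1ccc(OCC2CC2)cc1` carries a 1H-pyrazol-5-yl group instead; in this assay compound 2 gives 6%, the lowest of the two numbers, with compound 1 as its nearest neighbour. Among the measured compounds shown here, the single measured step, a number 2 percentage points lower from compound 1 to compound 2 (within the scatter), shows that exchanging this group has so far produced nothing beyond the scatter. On these data alone, compound 3 `N#Cc1c(N)nc(SCc2cnc[nH]2)c(C#N)c1-c1ccc(OCC2CC2)cc1` is still untested and differs from compound 2 by 1H-imidazol-5-yl in place of 1H-pyrazol-5-yl on a saturated chain carbon bound to a sulfur. For the measured compounds named here, because the only comparable step, a number 2 percentage points lower from compound 1 to compound 2 (within the scatter), stayed within the scatter, the expected step here is likewise none beyond the scatter. Compound 3 is therefore expected to give 7%, between -5% and 20%. The estimated step is a number 1 percentage points higher from compound 2 to compound 3 (within the scatter).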

Compound 3, a percentage reported as inhibition, at one concentration (the size of the read-out at that concentration, not a potency): 1%
Beside the measured number, compound 3's estimate is 6 percentage points above it; low and high end bracket the measured number.
By their numbers in this assay, from the lowest: compounds 3, 2 and 1 (each within the scatter of the next).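

In this assay the exchange of 1H-pyrazol-5-yl for 1H-imidazol-5-yl, two groups with the same atoms joined differently, gives a number 5 percentage points lower from compound 2 to compound 3 (within the scatter) and so shows no readable effect of how these ring atoms are joined. Replacing the (hydroxymethyl)carbamoyl group with 1H-imidazol-5-yl gives a number 7 percentage points lower from compound 1 to compound 3 (within the scatter) and so all three groups on this saturated chain carbon bound to a sulfur now stand within the scatter of one another. No measurement is available that could explain these numbers.

The compounds shown leave open whether any other group in this place, such as a carboxylic acid, an amine or a longer chain, would move the inhibition beyond the scatter. On these data alone, their potency also stays open, since a reading at one concentration gives only the size of the effect there.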